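The source may hold more compounds than are shown below. What is called first, only, known or untested is meant among the compounds shown, and "the series" means these compounds.

Among the compounds with values here, in a functional assay on A549/CDDP cells (Homo sapiens) for antiproliferative activity, read by MTT assay, with a stated time of 72 h (on this read-out higher numbers stand for weaker inhibition and lower numbers for stronger inhibition), three compounds on one shared core have numbers so far: compound 1 (`Cc1nc(C)c(/C=C/C(=O)/C=C/c2ccccc2O)nc1C`) gives 3900 nM and compound 2 (`Cc1nc(C)c(/C=C/C(=O)/C=C/c2ccccc2)nc1C`) gives 11900 nM while compound 3 (`Cc1nc(C)c(/C=C/C(=O)/C=C/c2ccc(F)cc2)nc1C`) gives 7440 nM on the same read-out. The number for compound 3 lies within the scatter of both others, as the steps (a 1.6-fold lower number from compound 2 to compound 3 (0.20 log units; within the scatter)) and (a 1.9-fold higher number from compound 1 to compound 3 (0.28 log units; within the scatter)) show. Within the data shown here, only the step (a 3.1-fold higher number from compound 1 to compound 2 (0.48 log units; beyond the scatter)) goes beyond the scatter.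

Compound 4 (`Cc1nc(C)c(/C=C/C(=O)/C=C/c2ccc(Cl)cc2)nc1C`) is still unmeasured. It differs from compound 3 by a single exchange (chloro in place of fluoro on an aromatic carbon), chloro in place of fluoro on an aromatic carbon, para to a large group. Among the measured compounds shown here, no chloro compound has been measured yet, so the closest guide is the step of fluoro in place of hydrogen (a 1.6-fold lower number from compound 2 to compound 3 (0.20 log units; within the scatter)), which stayed within the scatter. No step beyond the scatter is therefore expected in this assay for this exchange. The step is expected to stay small (a 1.1-fold lower number from compound 3 to compound 4 (0.03 log units; within the scatter)). The estimated value for compound 4 is 7000 nM with 3500 nM and 14000 nM as the expected ends of its range.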

Compound 4, half-maximal inhibitory concentration: 7490 nM
Compound 4: the middle estimate sits 1.1-fold (0.03 log units) below what was measured; measured number inside the range.
By their numbers in this assay, from the lowest: compounds 1, 3, 4 and 2 (each within the scatter of the next, the first and the last beyond it).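

In this assay, the exchange of 4-fluorophenyl for 4-chlorophenyl leaves the number where it was (a 1.0-fold higher number from compound 3 to compound 4 (0.00 log units; within the scatter)), so at this place, para to a large group, fluoro and chloro cannot be told apart. Chloro in place of hydrogen also stays within the scatter (a 1.6-fold lower number from compound 2 to compound 4 (0.20 log units; within the scatter)), as does 4-chlorophenyl in place of 2-hydroxyphenyl (a 1.9-fold higher number from compound 1 to compound 4 (0.28 log units; within the scatter)), which means that compound 4 cannot be separated from any of the other three compounds, even though compound 1 and compound 2 lie beyond the scatter of each other. Nothing on hand explains why fluoro and chloro read alike here.

The compounds shown leave open whether a methoxy or a nitrile at this same place would move the number beyond the scatter. They also leave open whether an amine in place of the hydroxy of compound 1 would read like that hydroxy or like the hydrogen of compound 2.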